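Methyl for Methoxycarbonyl on a Triazene Core

This account rests on a few compounds, and the source may have more. Where it says the series, first, only, none or still open, it means among the compounds named here.

Measured compounds:
compound 1, `COC(=O)c1cccc(/N=N/N(C)C)c1`, 3.42
compound 2, `CC(=O)/N=N/C(=O)c1ccccc1/N=N/N(C)C`, 3.05
compound 3, `CN(C)/N=N/c1ccc(C#N)cc1C(N)=O`, 3.46

The three measured compounds share a dimethyltriazene group on a benzene ring and were tested in a functional assay on L1210 cells (Mus musculus) for antiproliferative activity; on this read-out higher numbers stand for higher potency (the scale is a negative logarithm) and lower numbers for lower potency. Compound 1 gives 3.42, which is the second highest of the three numbers. Compound 3 lies closest to it with 3.46, a difference within the usual scatter, so the two cannot be ordered. Compound 2 lies furthest off with 3.05, a gap beyond the scatter, so compound 2 is the weaker of that pair. For the measured compounds named here, no pair among the measured compounds differs in only one place, so no single-step comparison is available.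

The unmeasured compound 4, `Cc1cccc(/N=N/N(C)C)c1`, differs from compound 1 in one place: methyl in place of methoxycarbonyl on an aromatic carbon. Going by the values given here, the measured values offer no direct guide to what this exchange does in this assay, since no pair of measured compounds shows it. The author therefore expects a step from compound 1 to compound 4 of a number 0.08 log units higher from compound 1 to compound 4 (within the scatter), small and probably not beyond the scatter. Compound 4 is estimated at 3.5, with a range from 3 to 4.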

Compound 4, logarithm of the reciprocal of the active concentration, log(1/C): 3.4
Beside the measured number, compound 4's estimate is 0.10 log units above it, within the range that was stated.
By their numbers in this assay, from the lowest: compound 2; then compounds 4, 1 and 3 (each within the scatter of the next).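

In this assay, for the compounds shown here, the exchange of methoxycarbonyl for methyl on an aromatic carbon, meta to a group of 5 heavy atoms, gives a number 0.02 log units lower from compound 1 to compound 4 (within the scatter), and this is the first comparison in which only one place differs. The exchange replaces a group of 4 heavy atoms, with 2 hydrogen-bond acceptors and a double bond, by a group of 1 heavy atom with no hydrogen-bond acceptors, yet the read-out does not separate the two compounds, so at this position neither the acceptors nor the larger group is needed to keep the number at this level. Nothing measured here accounts for how close the two numbers lie.

The compounds shown leave open whether a group of another kind at this position, such as an amine, a carboxylic acid or a longer chain, would move the number beyond the scatter. They also leave open whether the same exchange from methoxycarbonyl to methyl would be as silent on another aromatic carbon of the shared core.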